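Thioether replacing ether at the aromatic carbon

The source may report more compounds than this note shows. Statements on the series, on what has been measured and on what is new or still open speak of the compounds shown alone.

Measured compounds:
compound 1 `CC(C(=O)NCc1ccc(C(F)(F)F)cc1N1CCC(C)(C)CC1)c1ccc(NS(C)(=O)=O)c(F)c1`; in an assay on CHO cells for antagonist activity at transient receptor potential cation channel subfamily V member 1 (Homo sapiens), read by FLIPR (a lower number here means a stronger inhibitor, a higher number a weaker inhibitor), compound 1 gives 1.3 nM.
compound 2 `CC(C)CCOc1cc(C(F)(F)F)ccc1CNC(=O)C(C)c1ccc(NS(C)(=O)=O)c(F)c1`; in this assay compound 2 gives 0.5 nM.
compound 3 `CC(C(=O)NCc1ccc(C(F)(F)F)cc1OCc1ccccc1)c1ccc(NS(C)(=O)=O)c(F)c1`; in this assay compound 3 gives 0.9 nM.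

Compound 3 holds the second highest of the three numbers. Its nearest neighbour is compound 1: the step of a 1.4-fold lower number from compound 1 to compound 3 (0.16 log units; within the scatter) is within the scatter, so the two are not separated. The step of a 1.8-fold higher number from compound 2 to compound 3 (0.26 log units; within the scatter) is likewise within the scatter, and compound 2 is the furthest of the three from compound 3. Among the measured compounds shown here, the only step beyond the scatter is a 2.6-fold lower number from compound 1 to compound 2 (0.41 log units; beyond the scatter), a modest one.

Compound 4 `COc1ccc(CSc2cc(C(F)(F)F)ccc2CNC(=O)C(C)c2ccc(NS(C)(=O)=O)c(F)c2)cc1` carries the change ((4-methoxybenzyl)sulfanyl in place of benzyloxy on an aromatic carbon). All three measured steps concern the same aromatic carbon and thus bear on this change: one is modest, two are within the scatter, and every group tried there has given a low number in this assay. Nothing among them indicates a large move in either direction.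

For compound 4 the expected step is a 1.1-fold higher number from compound 3 to compound 4 (0.05 log units; within the scatter), not beyond the scatter. The estimate for compound 4 in this assay is 1 nM, with a range from 0.4 nM to 2.5 nM.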

Compound 4, inhibition constant: 2.3 nM
Beside the measured number, compound 4's estimate is 2.3-fold (0.36 log units) below it; low and high end bracket the measured number.
By their numbers in this assay, from the lowest: compounds 2, 3, 1 and 4 (each within the scatter of the next, the first and the last beyond it).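

In this assay, the replacement of benzyloxy by (4-methoxybenzyl)sulfanyl gives the first step out of compound 3 that lies beyond the scatter: a 2.6-fold higher number from compound 3 to compound 4 (0.41 log units; beyond the scatter). The same group is also separated from the isopentyloxy compound, with a 4.6-fold higher number from compound 2 to compound 4 (0.66 log units; beyond the scatter), the largest step among the four compounds, whereas a 1.8-fold higher number from compound 1 to compound 4 (0.25 log units; within the scatter) leaves it unseparated from the 4,4-dimethylpiperidin-1-yl compound. This aromatic carbon is therefore not indifferent to the group it carries, yet all steps across these four groups remain modest or within the scatter, and compound 4 still gives 2.3 nM.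

Two things change together in this step, oxygen giving way to sulfur and a methoxy group appearing on the benzyl ring, so the step cannot be assigned to either one, and the benzylsulfanyl and (4-methoxybenzyl)oxy groups would be needed to separate the two. The compounds shown also offer no evidence that accounts for the step.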